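Fluoro in place of hydrogen on the core of compound 1

This account rests on a few compounds, and the source may have more. Where it says the series, first, only, none or still open, it means among the compounds named here.

In a functional assay on MIA PaCa-2 cells (Homo sapiens) for cytotoxicity, read by WST assay, with a stated time of 24 h (on this read-out lower numbers stand for stronger inhibition and higher numbers for weaker inhibition), compound 1 (`COc1ccc2[nH]cc(/C=C(\C#N)C(=O)c3c[nH]c4ccccc34)c2c1`) gives 21200 nM as its reading. Among the measured compounds shown here, compound 2 (`COc1ccc2[nH]cc(/C=C(\C#N)C(=O)c3c[nH]c4ccc(OC)cc34)c2c1`) gives 28500 nM on the same read-out, and these two readings lie within the scatter of each other, so compound 1 stands level with its only measured neighbour.

Compound 3 (`COc1ccc2[nH]cc(/C=C(\C#N)C(=O)c3c[nH]c4cc(F)ccc34)c2c1`) is still unmeasured. The change from compound 1 (fluoro in place of hydrogen on an aromatic carbon) is fluoro in place of hydrogen on an aromatic carbon, meta to a fused ring and para to a fused ring.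

For the measured compounds named here, only one measured step bears on this change, and only loosely: a 1.3-fold higher number from compound 1 to compound 2 (0.13 log units; within the scatter) for methoxy in place of hydrogen on an aromatic carbon. Going by the values given here, no step with fluoro has been measured, so the expectation rests on that single small step with a different group. No step beyond the scatter is expected in this assay in either direction. The estimated step is a 1.2-fold lower number from compound 1 to compound 3 (0.07 log units; within the scatter) and stays within the scatter. Compound 3 is estimated at 18000 nM with an expected range from 6000 nM to 40000 nM on this read-out.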

Compound 3, half-maximal inhibitory concentration: > 50000 nM
Compound 3 gave a limit, no number (the forecaster's own chance of this, stated with the estimate: 10%); middle value at least 2.7-fold (0.44 log units) away from the limit.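

In this assay compound 3 reads > 50000 nM, which is a limit of the assay and not a number. Fluoro in place of hydrogen on this aromatic carbon, meta to a fused ring and para to a fused ring, gives an at least 2.3-fold higher number from compound 1 to compound 3 (0.37 log units; beyond the scatter), so a change of one heavy atom on the core of compound 1 is enough to weaken the reading beyond the scatter, whereas methoxy in place of hydrogen on an aromatic carbon gave only a 1.3-fold higher number from compound 1 to compound 2 (0.13 log units; within the scatter). The series is therefore not insensitive to substitution on this ring, although the size of the step has only a lower bound, which is set by the top of the assay range: the limit of > 50000 nM in this assay, at which 1 of the 3 values shown sits.

The compounds shown do not tell whether this weakening belongs to fluoro itself or to any substituent on this carbon, a question that chloro or an amine at the same place would address. How far compound 3 truly lies from compound 1 also stays open, and the data give no cause for the step.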